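A few compounds are considered here, and "the series" means these few. Any claim that something is new, unique, unknown or untested is made for them only; others in the source may bear on it.

Measured so far:
- compound 1, `CCCCCCS(=O)(=O)/C=C/c1ccc(O)c(O)c1`, 7300 nM
- compound 2, `O=S(=O)(/C=C/c1ccc(O)c(O)c1)CCCCCCCCO`, 6700 nM
- compound 3, `O=S(=O)(/C=C/c1ccc(O)c(O)c1)CCCCCCCCCCCO`, 22600 nM

In a functional assay, read by fluorescence and spectrophotometry, with a stated time of 1 h (a higher number here means that more compound is needed for the effect, a lower number that less compound is needed), compound 1 gives 7300 nM, the second highest of the three numbers. Compound 2 sits nearest to it: the change from compound 1 to compound 2 is a 1.1-fold lower number from compound 1 to compound 2 (0.04 log units; within the scatter). Compound 3 is furthest away, with a 3.1-fold higher number from compound 1 to compound 3 (0.49 log units; beyond the scatter). Between the two hydroxylated chains, the step is a 3.4-fold higher number from compound 2 to compound 3 (0.53 log units; beyond the scatter).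

Compound 4, `O=S(=O)(/C=C/c1ccc(O)c(O)c1)CC1CC1`, is a new compound that is yet to be measured in this assay. It differs from compound 1 by cyclopropyl in place of pentyl on a saturated chain carbon bound to a sulfonyl sulfur. The chain bound to the sulfonyl sulfur is thus made shorter and closed into a small ring, while the shared core is kept.

For the measured compounds named here, none of the measured steps makes this change directly. The steps from compound 1 to compound 2 and from compound 1 to compound 3 both lengthen the chain at its far end, and only the longer of the two extensions moves the number beyond the scatter. A shorter chain has not been tried, so the direction is open. The expected step in this assay, a 1.0-fold higher number from compound 1 to compound 4 (0.01 log units; within the scatter), is therefore taken as none beyond the scatter, with a wide range. Compound 4 is estimated at 7500 nM, between 2500 nM and 22000 nM.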

Compound 4, half-maximal effective concentration: 10500 nM
Compound 4: middle estimate off by 1.4-fold (0.15 log units), on the low side, and the stated range covers the measured number.
By their numbers in this assay, from the lowest: compounds 2, 1 and 4 (each within the scatter of the next); then compound 3.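

In this assay, putting cyclopropyl in place of pentyl on a saturated chain carbon bound to a sulfonyl sulfur gives a 1.4-fold higher number from compound 1 to compound 4 (0.16 log units; within the scatter). For the compounds shown here, this is the first look at this position with a smaller group, and it shows that the hexyl chain of compound 1 can become cyclopropylmethyl without a change that stands clear of the scatter, whereas lengthening the chain with a terminal hydroxy group can give a 3.1-fold higher number from compound 1 to compound 3 (0.49 log units; beyond the scatter). No independent data bear on this result, so the four compounds describe what happens at this position but do not explain it.

Since this single change both shortens the chain and closes it into a ring, the effects of those two differences cannot be told apart here, and an open propyl or ethyl chain would be the natural comparison. Also open, going by these compounds, is how the number would respond to a larger ring such as cyclobutyl or cyclohexyl, or to an amine or a carboxylic acid at the end of the hexyl chain.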